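Chloro in Place of Methyl: A Small Lipophilicity Step

The source may hold more compounds than are shown below. What is called first, only, known or untested is meant among the compounds shown, and "the series" means these compounds.

Measured compounds:
- Compound 1, `CCOc1ccccc1-c1ccc(-c2nc3cnccc3cc2C#N)cc1`: 3.8
- Compound 2, `CCOc1ccccc1-c1ccc(-c2nc3cncc(Cl)c3c(N[C@H](CC)C(N)=O)c2C#N)cc1`: 3.7
- Compound 3, `CC[C@@H](Nc1c(C#N)c(-c2ccc(-c3cccc(C)c3)cc2)nc2cnccc12)C(N)=O`: 3

These three compounds were compared in a physicochemical assay for lipophilicity, read by HPLC, at pH 7.5; a higher number here means a more lipophilic compound, a lower number a more polar compound. Compound 3 stands lowest of the three: compound 2 sits higher by a gap beyond the scatter, and compound 1 sits higher still. Compound 4, `CC[C@@H](Nc1c(C#N)c(-c2ccc(-c3cccc(Cl)c3)cc2)nc2cnccc12)C(N)=O`, has not yet been measured. It differs from compound 3 in one place: chloro in place of methyl on an aromatic carbon. Exchanging one single heavy atom for another, with no change in ring count, donors or acceptors, is a small edit. The step from compound 3 to compound 4 is expected to be small and upward, a number 0.20 log units higher from compound 3 to compound 4 (within the scatter), possibly within the scatter. For compound 4 in this assay the estimate is 3.2, with a range from 2.8 to 3.6.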

Compound 4, distribution coefficient: 3.1
Estimate against measurement, compound 4: 0.10 log units above, and the stated range covers the measured number.
By their numbers in this assay, from the lowest: compounds 3 and 4 (each within the scatter of the next); then compounds 2 and 1 (each within the scatter of the next).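

In this assay, chloro in place of methyl on this aromatic carbon gives a number 0.10 log units higher from compound 3 to compound 4 (within the scatter), so at this place the two groups cannot be told apart by this read-out. Compound 3 and compound 4 form the only pair shown that differs in one place, which makes this the first direct reading of a single change in the series. Nothing measured here gives a reason for this closeness.

As far as these compounds go, whether an amine or a carboxylic acid at this same place would shift the number beyond the scatter stays open. So does whether chloro and methyl would also stay this close on the ring's other carbons.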